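Swapping a Chloro for a Methoxy on the Aryl Ring

The source may hold more compounds than are shown below. What is called first, only, known or untested is meant among the compounds shown, and "the series" means these compounds.

Of the compounds shown here, three sharing one core have been measured in a functional assay on aorta (strain Wistar) for inhibition, with Thoracic aorta (Rattus norvegicus) as the target; a higher number here means a weaker inhibitor, a lower number a stronger inhibitor. Compound 1 `COc1nc(-c2cc3ccccc3o2)cc(-c2cccc3ccccc23)c1C#N` gives 359000 nM. Compound 2 `COc1nc(-c2cc3ccccc3o2)cc(-c2ccc(Cl)cc2)c1C#N` gives 286000 nM. Compound 3 `CCOc1nc(-c2cc3ccccc3o2)cc(-c2ccc(Cl)cc2)c1C#N` gives 221000 nM. Compound 2 thus stands second highest of the three, but its gaps to compound 1 and to compound 3 both lie within the scatter of repeated measurements, so the three cannot be told apart.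

Among the compounds with values here, the one step between compounds differing in a single place, a 1.3-fold lower number from compound 2 to compound 3 (0.11 log units; within the scatter), concerns the ether chain and not the aryl ring.

Compound 4 `COc1ccc(-c2cc(-c3cc4ccccc4o3)nc(OC)c2C#N)cc1` is not yet measured. It differs from compound 2 in one place: methoxy in place of chloro on an aromatic carbon. No measured step touches the aryl ring, so nothing among these compounds speaks for a shift in either direction, and the only known step was itself within the scatter.

Compound 4 is therefore expected to show no change at the digits printed from compound 2 to compound 4 (within the scatter), no change beyond the scatter. In this assay compound 4 is estimated to give 286000 nM, with a likely range from 130000 nM to 630000 nM.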

Compound 4, half-maximal inhibitory concentration: 262000 nM
Compound 4: middle estimate off by 1.1-fold (0.04 log units), on the high side; the range from low to high includes it.
By their numbers in this assay, from the lowest: compounds 3, 4, 2 and 1 (each within the scatter of the next).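

Within the data shown here, replacing the 4-chlorophenyl with a 4-methoxyphenyl gives a 1.1-fold lower number from compound 2 to compound 4 (0.04 log units; within the scatter) in this assay, and this is the first measured step on the aryl ring, at the aromatic carbon para to a large group. Chloro (1 heavy atom, 0 hydrogen-bond acceptors) and methoxy (2 heavy atoms, 1 hydrogen-bond acceptor) differ in these counts, yet the two compounds cannot be told apart in this assay, so neither group stands out here. Nothing measured on these compounds offers an explanation for this result.

From the compounds shown here alone, whether an amine or a carboxylic acid on the same aromatic carbon would move the number beyond the scatter remains open. Going by these compounds, it is also open whether the swap from chloro to methoxy would read the same with the ether chain of compound 3 in place.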